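Methyl on the hydroxy oxygen: expected effect

This account rests on a few compounds, and the source may have more. Where it says the series, first, only, none or still open, it means among the compounds named here.

Compound 1 `O/N=C(\CCN1CCN(c2ccccn2)CC1)c1ccccc1`, compound 2 `Cc1ccccc1/C(CCN1CCN(c2ccccn2)CC1)=N/O` and compound 3 `Cc1ccccc1/C(CCN1CCN(c2ccccn2)CC1)=N\O` share one core and differ only at the aromatic ring and in the configuration drawn at the double bond. In a functional assay on HEK293 cells with D(4) dopamine receptor (Homo sapiens) as the target, read by FLIPR (a lower number here means that less compound is needed, a higher number that more compound is needed for the effect), compound 1 gives 4.4 nM, compound 2 gives 4.2 nM and compound 3 gives 20.3 nM. Compound 2 carries the lowest number of the three, but the step of a 1.0-fold lower number from compound 1 to compound 2 (0.02 log units; within the scatter) is within the scatter, so compound 2 and compound 1 are not separated. The step of a 4.8-fold higher number from compound 2 to compound 3 (0.68 log units; beyond the scatter) is modest and beyond the scatter; it rests on (the fact that compounds 2 and 3 differ only in the configuration as drawn).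

Compound 4 `CO/N=C(\CCN1CCN(c2ccccn2)CC1)c1ccccc1C` is unmeasured. It differs from compound 2 by methyl in place of hydrogen on an oxygen, hydroxy to methoxy. Neither measured step touches this oxygen: one concerns the aromatic ring, the other the configuration, so they give only the scale of changes seen so far. The expected step in this assay is a 1.7-fold higher number from compound 2 to compound 4 (0.22 log units; within the scatter), a drift toward a higher number that may stay within the scatter. Compound 4 is estimated at 7 nM, with a range of 2.5 nM to 25 nM.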

Compound 4, half-maximal effective concentration: 74 nM
Beside the measured number, compound 4's estimate is 11-fold (1.02 log units) below it; the measured number lies above the stated range.
By their numbers in this assay, from the lowest: compounds 2 and 1 (each within the scatter of the next); then compound 3; then compound 4.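

In this assay, hydroxy to methoxy gives an 18-fold higher number from compound 2 to compound 4 (1.25 log units; beyond the scatter), so this oxygen is a place where adding a single heavy atom moves the number strongly. The same methyl-for-hydrogen exchange on the aromatic ring gave a 1.0-fold lower number from compound 1 to compound 2 (0.02 log units; within the scatter), and changing the configuration gave a 4.8-fold higher number from compound 2 to compound 3 (0.68 log units; beyond the scatter), so the oxygen shows the largest single-place step among these compounds and the effect of a methyl depends on where it stands. Nothing available bears on the cause of the step at this oxygen.

These compounds leave open whether an ethyl, a longer chain or an amine-bearing chain on this oxygen would raise the number further or bring it back. Going by these compounds, it also remains open whether methoxy gives a step of similar size in the configuration of compound 3.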